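A few compounds are considered here, and "the series" means these few. Any claim that something is new, unique, unknown or untested is made for them only; others in the source may bear on it.

Of the compounds shown here, two have been tested in a functional assay on the whole organism (strain Swiss albino) with Mus musculus as the target, in the maximal electroshock model, with a stated time of 4 h; a lower number here means that less compound is needed, a higher number that more compound is needed for the effect. Compound 1 `O=C(N/N=C/c1ccc(F)cc1)Nc1cccc2ccccc12` carries a fluoro group on the outer aromatic ring, and in this assay compound 1 needs 300 mg/kg to protect the animals. Compound 2 `O=C(N/N=C/c1ccc(Br)cc1)Nc1cccc2ccccc12` carries a bromo group in the same position, and in this assay compound 2 needs 300 mg/kg. For the measured compounds named here, the one step between them, no change at the digits printed from compound 1 to compound 2 (within the scatter), therefore shows that swapping one halogen for the other made no difference that could be told apart from the usual noise of the measurement.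

Compound 3 `CN(C)c1ccc(/C=N/NC(=O)Nc2cccc3ccccc23)cc1` is the next member, and it differs from compound 2 in one place: dimethylamino in place of bromo on an aromatic carbon. Going by the values given here, no measured step covers a change of this kind, since the only step recorded swaps one halogen for another and is flat. Among the compounds with values here, that flat step is the sole guide, so the expected step from compound 2 to compound 3 is no change at the digits printed from compound 2 to compound 3 (within the scatter), and compound 3 is estimated to need 300 mg/kg in this assay, within a range from 100 mg/kg to 600 mg/kg.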

Compound 3, minimum effective dose: 100 mg/kg
Compound 3: middle estimate off by 3.0-fold (0.48 log units), on the high side; the measured number falls inside the stated range.
By their numbers in this assay, from the lowest: compound 3; then compounds 1 and 2 (each within the scatter of the next).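

In this assay the swap between halogens on this aromatic carbon had shown nothing, but dimethylamino in place of bromo gives a 3.0-fold lower number from compound 2 to compound 3 (0.48 log units; beyond the scatter) and dimethylamino in place of fluoro gives a 3.0-fold lower number from compound 1 to compound 3 (0.48 log units; beyond the scatter). For the compounds shown here, the position is therefore not indifferent to what sits on it, and compound 3 is the first compound here that needs less compound for the effect than the others. The change from bromo to dimethylamino replaces one heavy atom and no hydrogen-bond acceptor with three heavy atoms and one hydrogen-bond acceptor, but no measurement at hand explains the lower dose.

From the compounds shown here alone, it remains open whether the nitrogen matters or simply a larger group at this carbon: a plain amino group, a methoxy group or an isopropyl group would help to separate these two readings. A diethylamino group would show whether longer chains on the nitrogen keep the gain, and moving dimethylamino to another carbon of the ring would show how much depends on its place.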